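Sulfonyl group variation at the weak end of the series

A few compounds are considered here, and "the series" means these few. Any claim that something is new, unique, unknown or untested is made for them only; others in the source may bear on it.

Compound 1 `Cc1cccc(S(=O)(=O)Nc2ccc3oc(-c4ccccc4)nc3c2)c1` in an assay on cells for inhibition of HSP60/HSP10 (Homo sapiens), with a stated time of 60 min (on this read-out lower numbers stand for stronger inhibition and higher numbers for weaker inhibition), gives > 100000 nM, which is a limit of the assay and not a number. Compound 2 `O=S(=O)(Nc1ccc2oc(-c3ccccc3)nc2c1)c1cccs1` in this assay gives 90000 nM. Compound 3 `O=S(=O)(Nc1ccc2oc(-c3ccccc3)nc2c1)c1ccc(F)c(C(F)(F)F)c1` in this assay gives 69000 nM.

Compound 2 stands highest of the two numbers recorded, with compound 3 nearest; the gap between them lies within the scatter. Within the data shown here, the one measured step at the sulfonyl sulfur, an at least 1.1-fold lower number from compound 1 to compound 2 (0.04 log units; that floor lies within the scatter), is bounded only at its floor, since compound 1 sits at the limit of > 100000 nM in this assay, at which 1 of the 3 values shown sits.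

Compound 4 `CS(=O)(=O)Nc1ccc2oc(-c3ccccc3)nc2c1` carries a smaller group at the same place: methyl in place of thiophen-2-yl on a sulfonyl sulfur. Among the measured compounds shown here, no measured step involves methyl here, and the single related step from compound 1 to compound 2 is too shallow to set a direction. The expectation for compound 4 in this assay is therefore a step of a 1.1-fold higher number from compound 2 to compound 4 (0.05 log units; within the scatter), essentially no change beyond the scatter, with a real chance that only a limit is returned. Compound 4 is estimated at 100000 nM, between 40000 nM and 250000 nM.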

Compound 4, half-maximal inhibitory concentration: > 100000 nM
Compound 4: only a limit was reported; the forecaster's own chance of this, stated with the estimate: 45%; the middle value sits exactly at the limit.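

In this assay compound 4 gives > 100000 nM, which is a limit of the assay and not a number. Methyl is the only group on the sulfonyl sulfur here without a ring, and its one readable result, an at least 1.1-fold higher number from compound 2 to compound 4 (0.04 log units; that floor lies within the scatter), sets a floor and no size, so the change from thiophen-2-yl shows no shift beyond the scatter and does not exclude a larger one. The step from compound 1 to compound 4 cannot be read, and a compound with a ring and one without end alike at the same limit: the limit of > 100000 nM in this assay, at which 2 of the 4 values shown sit.

On these data alone, how far compound 1 and compound 4 actually lie past that limit stays open. Also open, as far as these compounds go, is whether a longer chain in place of methyl, or a carboxylic acid or an amine on the sulfonyl ring, would give a number clearly beyond the scatter of these values.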